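The source may hold more compounds than are shown below. What is called first, only, known or untested is meant among the compounds shown, and "the series" means these compounds.

Measured in a functional assay on HepG2 cells (Homo sapiens) for antiproliferative activity, read by XTT assay, with a stated time of 72 h; on this read-out higher numbers stand for weaker inhibition and lower numbers for stronger inhibition:
- compound 1 `COc1ncnc2c1c(-c1ccccc1)cn2[C@@H]1O[C@H](CO)[C@@H](O)[C@H]1O`: > 20000 nM (a limit)
- compound 2 `Nc1nc(N)c2c(-c3cc4ccccc4o3)cn([C@@H]3O[C@H](CO)[C@@H](O)[C@H]3O)c2n1`: > 20000 nM (a limit)

Compound 2 gives > 20000 nM, which is a limit of the assay and not a number. The whole measured set stands on (the limit of > 20000 nM in this assay, at which 2 of the 2 values shown sit), so neither compound has a numerical potency to compare.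

Compound 3 `Cc1nc(N)c2c(-c3cc4ccccc4o3)cn([C@@H]3O[C@H](CO)[C@@H](O)[C@H]3O)c2n1` is the next compound to read. It differs from compound 2 by methyl in place of amino on an aromatic carbon, between two ring nitrogen atoms. Among the compounds with values here, no measured pair shows what this change does, so its size cannot be taken from an earlier step.

In this assay, no step beyond the scatter is expected, and neither direction is favoured. That expectation rests on compound 2 and its limit of > 20000 nM. The estimated change is a number no higher from compound 2 to compound 3 (the limit leaves the size open), and a further reading that is only a limit would fit it.

For compound 3 the estimate is 20000 nM, with an expected range of 6000 nM to 40000 nM.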

Compound 3, half-maximal inhibitory concentration: > 20000 nM
Compound 3 was reported as a limit (the forecaster's own chance of this, stated with the estimate: 75%); the middle value lies on the limit itself.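

In this assay compound 3 gives > 20000 nM, which is a limit of the assay and not a number. Compound 2 also stands at a limit, so no step can be read from compound 2 to compound 3. The compounds shown leave open what methyl in place of amino on an aromatic carbon does to potency.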